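The source may report more compounds than this note shows. Statements on the series, on what has been measured and on what is new or still open speak of the compounds shown alone.

Measured in a functional assay on HT cells (Homo sapiens) for antiproliferative activity, read by fluorescence, with a stated time of 72 h; a higher number here means a weaker inhibitor of growth, a lower number a stronger inhibitor of growth:

- compound 1 `CC(O)CSc1nc(NCc2ccc(-c3ccccn3)cc2)c2[nH]nc(C(C)C)c2n1` gives 62 nM
- compound 2 `CC(C)c1n[nH]c2c(NCc3ccc(-c4ccccn4)cc3)nc(SC(C)C(C)O)nc12` gives 190 nM
- compound 3 `CC(C)c1n[nH]c2c(NCc3ccc(-c4ccccn4)cc3)nc(SC3CCCCC3O)nc12` gives 636 nM

Compound 3 has the highest number of the three, which makes it the weakest inhibitor of growth here. The next compound is compound 4 `CC(C)c1n[nH]c2c(NCc3ccc(-c4ccccn4)cc3)nc(S)nc12`, with hydrogen in place of 2-hydroxycyclohexyl on a sulfur as its change. Going by the values given here, the steps that bear on this are a 10-fold higher number from compound 1 to compound 3 (1.01 log units; beyond the scatter) and a 3.3-fold higher number from compound 2 to compound 3 (0.52 log units; beyond the scatter), along with a 3.1-fold higher number from compound 1 to compound 2 (0.49 log units; beyond the scatter). They show that the group on the sulfur can move the number, but every measured compound keeps a hydroxy-bearing group there. Their direction therefore cannot simply be carried over, and no clear change is expected in this assay. The expected step is a 1.4-fold higher number from compound 3 to compound 4 (0.15 log units; within the scatter), with wide uncertainty. For compound 4 the estimated value is 900 nM, with an expected range from 150 nM to 5000 nM.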

Compound 4, concentration for 50% growth inhibition: 2760 nM
Beside the measured number, compound 4's estimate is 3.1-fold (0.49 log units) below it, and the stated range covers the measured number.
By their numbers in this assay, from the lowest: compound 1; then compound 2; then compound 3; then compound 4.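

In this assay hydrogen on the sulfur, with the whole side group gone, gives a 4.3-fold higher number from compound 3 to compound 4 (0.64 log units; beyond the scatter) and a 15-fold higher number from compound 2 to compound 4 (1.16 log units; beyond the scatter) and a 45-fold higher number from compound 1 to compound 4 (1.65 log units; beyond the scatter) in the widest comparison. So all three hydroxy-bearing groups on this sulfur give stronger inhibitors of growth than hydrogen does, which the earlier compounds, all carrying such a group, could not show. Nothing measured here gives a reason for this.

The compounds shown leave open whether the hydroxy matters or the carbon group alone does. A plain propyl chain on the sulfur, or a chain ending in an amine or a carboxylic acid, would help separate the two.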